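This account rests on a few compounds, and the source may have more. Where it says the series, first, only, none or still open, it means among the compounds named here.

Compound 1 `COc1ccccc1/C=c1/[nH]c(=O)/c(=C\c2ccccc2OC)[nH]c1=O`: "not active" (no number reported)
Compound 2 `C=CCn1c(=O)/c(=C\c2cccc(F)c2)[nH]c(=O)/c1=C\c1ccccc1OC`: 9100 nM

In a functional assay on HeLa cells (Homo sapiens) for cytotoxicity, read by CCK-8 assay, with a stated time of 72 h (a lower number here means a stronger inhibitor, a higher number a weaker inhibitor), compound 1 gives "not active" (no number reported), so there is no number for it to stand on; it is simply reported as not active. Compound 2 carries an allyl group on one ring nitrogen and a fluorine in place of one methoxy group, and in this assay compound 2 gives 9100 nM. Among the measured compounds shown here, no step between these two is given, and they differ in more than one place, so their values can only be read side by side: one inactive, the other weakly active.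

Compound 3 `COc1ccccc1/C=c1/[nH]c(=O)/c(=C\c2ccccc2OC)n(C)c1=O` differs from compound 1 by methyl in place of hydrogen on an aromatic nitrogen. For the measured compounds named here, no measured step of this kind exists. A modest gain in this assay is expected, from inactive toward weak activity, since compound 2 with a group on a ring nitrogen reaches 9100 nM. Compound 3 is expected to give about 20000 nM, within 5000 nM to 80000 nM, with a real chance that only a limit is reported.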

Compound 3, half-maximal inhibitory concentration: "not active" (no number reported)
Compound 3: no number reported, so the estimate cannot be set against anything.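

In this assay compound 1 and compound 3 are both reported as not active, so no step can be read for methyl in place of hydrogen on the aromatic nitrogen. Whether that methyl changes activity in a compound with a measurable value stays open, and no measurement shown here bears on this result.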